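This account rests on a few compounds, and the source may have more. Where it says the series, first, only, none or still open, it means among the compounds named here.

Of the compounds shown here, two built on the same core have been measured in a functional assay on Huh-7 cells (Homo sapiens) for inhibition, read by sulforhodamine B assay, with a stated time of 72 h; a higher number here means a weaker inhibitor, a lower number a stronger inhibitor. Compound 1 `COc1ccc2cc(C(C)c3nnc4n3N=C(c3ccc(C(F)(F)F)cc3)CS4)ccc2c1` gives 14800 nM. Compound 2 `CC(c1ccc(-c2ccccc2)c(F)c1)c1nnc2n1N=C(c1ccc(C(F)(F)F)cc1)CS2` gives 9400 nM, the lower of the two numbers, though its gap to compound 1 lies within the scatter, so no order between them can be claimed. Compound 3 `COc1ccc(C2=Nn3c(nnc3C(C)c3ccc(-c4ccccc4)c(F)c3)SC2)cc1` is not yet measured. It differs from compound 2 in one place: methoxy in place of trifluoromethyl on an aromatic carbon. Among the measured compounds shown here, no measured pair shows what this swap does, so the expectation rests on the two numbers alone. For compound 3 the expected step is a 1.3-fold higher number from compound 2 to compound 3 (0.11 log units; within the scatter), no bigger than the scatter. Compound 3 is estimated at 12000 nM, between 5000 nM and 30000 nM.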

Compound 3, half-maximal inhibitory concentration: 4300 nM
Compound 3: the middle estimate sits 2.8-fold (0.45 log units) above what was measured; measured number below the stated range.
By their numbers in this assay, from the lowest: compound 3; then compounds 2 and 1 (each within the scatter of the next).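

In this assay, methoxy in place of trifluoromethyl gives a 2.2-fold lower number from compound 2 to compound 3 (0.34 log units; beyond the scatter). Among the compounds shown here, compound 1 and compound 2 both carry trifluoromethyl here, so this is the first sign that the group at this position can shift the number, though the step is modest. No measurement shown explains why the number moves. On these data alone, whether other groups here, such as a hydroxyl, an amine or a longer ethoxy chain, would lower the number further remains open, as does whether this swap would act similarly on compound 1.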